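From Nitrile to Chlorine in a Free Fatty Acid Receptor Series

The source may report more compounds than this note shows. Statements on the series, on what has been measured and on what is new or still open speak of the compounds shown alone.

Compound 1 `Cc1nn(-c2ccccn2)c2cc(-c3ccc(CC(C)(C)C(=O)O)cc3)ccc12`: > 100000 nM, a limit of the assay
Compound 2 `COc1cc(CCC(=O)O)ccc1-c1ccc2c(C)nn(-c3ccccn3)c2c1`: 8200 nM
Compound 3 `Cc1nn(-c2ccccn2)c2cc(-c3ccc(CCC(=O)O)cc3C#N)ccc12`: 6100 nM

Of the compounds shown here, three have been measured in a functional assay on cells for agonist activity at Free fatty acid receptor 1 (Mus musculus), read by FLIPR and calcium flux, with a stated time of 5 min; a higher number here means that more compound is needed for the effect, a lower number that less compound is needed. Compound 1 gives only a limit, > 100000 nM, the situation described by the limit of > 100000 nM in this assay, at which 1 of the 3 values shown sits. Compound 2 gives 8200 nM and compound 3 gives 6100 nM; compound 3 thus holds the lowest of the two numbers, with compound 2 nearest to it and within the scatter. Compound 4 `Cc1nn(-c2ccccn2)c2cc(-c3ccc(CCC(=O)O)cc3Cl)ccc12` is the next compound, and it differs from compound 3 by chloro in place of cyano on an aromatic carbon. Within the data shown here, the only measured step at the same aromatic carbon is a 1.3-fold lower number from compound 2 to compound 3 (0.13 log units; within the scatter), which left the number within the scatter. Among the measured compounds shown here, no measured step involves chloro. The step of a 1.0-fold lower number from compound 3 to compound 4 (0.01 log units; within the scatter) is therefore expected to be small. Compound 4 is expected to give 6000 nM, between 2000 nM and 18000 nM.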

Compound 4, half-maximal effective concentration: 1200 nM
Compound 4: middle estimate off by 5.0-fold (0.70 log units), on the high side; measured number below the stated range.
By their numbers in this assay, from the lowest: compound 4; then compounds 3 and 2 (each within the scatter of the next). At a limit, above all of these: compound 1.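

At this aromatic carbon, ortho to a large group, swapping methoxy for cyano had left the number within the scatter, which gave no sign that the position responds to its substituent. In this assay, chloro in place of cyano now gives a 5.1-fold lower number from compound 3 to compound 4 (0.71 log units; beyond the scatter) and chloro in place of methoxy gives a 6.8-fold lower number from compound 2 to compound 4 (0.83 log units; beyond the scatter), so the group on this carbon does matter. Nothing measured here accounts for the change.

As far as these compounds go, whether bromine, fluorine or a methyl group on this carbon would match chloro remains open. So does whether a longer chain in place of the 2-carboxyethyl group would keep the lower number.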